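Aryl amine variation at the amide-linked hydroxamate series

The source may report more compounds than this note shows. Statements on the series, on what has been measured and on what is new or still open speak of the compounds shown alone.

Measured in an assay on cells for inhibition of protein deacetylase HDAC6 (Homo sapiens), with a stated time of 3 h; on this read-out higher numbers stand for weaker inhibition and lower numbers for stronger inhibition:
compound 1 `O=C(CCCCCCC(=O)Nc1cc2ncnc(Nc3ccc(Cl)cc3F)c2s1)NO`: 37 nM
compound 2 `COc1ccc(Nc2ncnc3cc(NC(=O)CCCCCCC(=O)NO)sc23)c(C)c1`: 111 nM

Compound 2 gives the highest of the two numbers, set apart from compound 1 by a 3.0-fold higher number from compound 1 to compound 2 (0.48 log units; beyond the scatter). Compound 3 `N#Cc1cccc(Nc2ncnc3cc(NC(=O)CCCCCCC(=O)NO)sc23)c1` differs from compound 2 in one place: 3-cyanophenyl in place of 4-methoxy-2-methylphenyl on a nitrogen on an aromatic ring. Going by the values given here, the only step that bears on this change is the one from compound 1 to compound 2, at the same nitrogen, which was modest. A step of comparable size is expected in this assay, with direction uncertain since no other aryl variants are available. For compound 3 the expected step is a 1.4-fold lower number from compound 2 to compound 3 (0.14 log units; within the scatter), giving an estimate of 80 nM (range 25 nM to 250 nM).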

Compound 3, half-maximal inhibitory concentration: 20.1 nM
For compound 3 the middle estimate is 4.0-fold (0.60 log units) above the measured one; the measured number lies below the stated range.
By their numbers in this assay, from the lowest: compounds 3 and 1 (each within the scatter of the next); then compound 2.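

At this nitrogen in this assay the aryl group can move the number in either direction: 3-cyanophenyl gives a 5.5-fold lower number from compound 2 to compound 3 (0.74 log units; beyond the scatter) and so reverses a 3.0-fold higher number from compound 1 to compound 2 (0.48 log units; beyond the scatter) in direction. Replacing 4-chloro-2-fluorophenyl with 3-cyanophenyl gives a 1.8-fold lower number from compound 1 to compound 3 (0.27 log units; within the scatter) so a ring without halogen can match compound 1. No measured evidence accounts for either step.

From the compounds shown here alone, whether the nitrile itself or the loss of the methoxy and methyl groups drives the step remains open. Unsubstituted phenyl, 3-methoxyphenyl and 4-cyanophenyl would help separate these readings.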